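The source may hold more compounds than are shown below. What is called first, only, known or untested is meant among the compounds shown, and "the series" means these compounds.

In a functional assay on HEL cells (Homo sapiens) for cytotoxicity, read by microscopy (on this read-out higher numbers stand for lower toxicity in this test and lower numbers for higher toxicity in this test), compound 3 `C#CCCCc1cc2cn([C@H]3C[C@H](O)[C@@H](CO)O3)c(=O)nc2o1` sits beside two close relatives built on the same core. Compound 1 `CCCCCCCc1cc2cn([C@H]3C[C@H](O)[C@@H](CO)O3)c(=O)nc2o1` reaches only the limit of > 50000 nM in this assay. Compound 2 `C=CCCCCc1cc2cn([C@H]3C[C@H](O)[C@@H](CO)O3)c(=O)nc2o1` likewise stops at the limit of > 200000 nM. Compound 3 itself stands at the limit of > 200000 nM, namely (the limit of > 200000 nM in this assay, at which 2 of the 3 values shown sit). Compound 4 `C#CCCCCCc1cc2cn([C@H]3C[C@H](O)[C@@H](CO)O3)c(=O)nc2o1` differs from it by but-3-yn-1-yl in place of ethynyl on a saturated chain carbon, three bonds along the chain from an aromatic carbon. The steps that touch compound 3, a step that the two limits leave unreadable from compound 1 to compound 3 and a step that the two limits leave unreadable from compound 2 to compound 3, both run between limits and give no readable size, and a step that the two limits leave unreadable from compound 1 to compound 2 is equally blank. Nothing here points to a shift in this assay in either direction. Compound 4 is therefore expected at 200000 nM, within a range from 50000 nM to 400000 nM, most likely reported again only as a limit. The expected step is a number no higher from compound 3 to compound 4 (the limit leaves the size open).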

Compound 4, minimum cytotoxic concentration: > 200000 nM
Compound 4 was reported as a limit; the forecaster's own chance of this, stated with the estimate: 85%; the middle value lies on the limit itself.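

Compound 4, like compound 1, compound 2 and compound 3, is reported only as a limit in this assay, so none of its steps to them can be read. The compounds shown leave open whether changing the chain shifts toxicity at all.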